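Swapping the nitrile for trifluoromethoxy on the sulfonyl arene

This account rests on a few compounds, and the source may have more. Where it says the series, first, only, none or still open, it means among the compounds named here.

Compound 1 `CC1CCN(C2CCN(S(=O)(=O)c3ccc(C#N)cc3)CC2)CC1` is the weaker of the two measured compounds in a functional assay on DLD-1 cells (Homo sapiens) for antiproliferative activity, read by CellTiter-Glo, with a stated time of 72 h (on this read-out lower numbers stand for stronger inhibition and higher numbers for weaker inhibition), where compound 1 gives 2800 nM. Its partner, compound 2 `CC1CCN(C2CCN(S(=O)(=O)c3ccc(Br)c(Cl)c3)CC2)CC1`, gives 12 nM in this assay; the shift of a 230-fold lower number from compound 1 to compound 2 (2.37 log units; beyond the scatter) shows how much the group on the sulfonyl arene can matter. Compound 3 `CC1CCN(C2CCN(S(=O)(=O)c3ccc(OC(F)(F)F)cc3)CC2)CC1` is a further variation on compound 1: trifluoromethoxy in place of cyano on an aromatic carbon. Going by the values given here, no measured step swaps cyano for trifluoromethoxy, so the step from compound 1 to compound 2 is the only guide, and it concerns a different replacement. A sizeable lowering is nonetheless expected, smaller and far less certain than that step. The expected outcome for compound 3 is a step of a 14-fold lower number from compound 1 to compound 3 (1.15 log units; beyond the scatter) in this assay. Compound 3 is therefore estimated at 200 nM, within a range from 30 nM to 1200 nM.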

Compound 3, half-maximal inhibitory concentration: 16 nM
The estimate for compound 3 lay 13-fold (1.10 log units) above the measured number; the whole stated range lies above it.
By their numbers in this assay, from the lowest: compounds 2 and 3 (each within the scatter of the next); then compound 1.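

In this assay, going by these compounds alone, the step of a 180-fold lower number from compound 1 to compound 3 (2.24 log units; beyond the scatter) shows that the single trifluoromethoxy group, on this aromatic carbon para to a large group, goes with a drop as large as the one for the 4-bromo-3-chlorophenyl ring, a 230-fold lower number from compound 1 to compound 2 (2.37 log units; beyond the scatter). Compounds 2 and 3 lie within the scatter of each other, so the low number is not tied to one particular replacement, and of the three compounds only compound 1, with its cyano group, stands apart. Nothing measured here explains why these replacements lower the number so strongly.

As far as these compounds go, it remains open how an amine or a carboxylic acid on this same carbon would behave. The compounds shown also leave open whether a carbonyl in place of the sulfonyl link would keep these low numbers.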